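Sulfonamide series on the shared core: the step to compound 4

The compounds below may be only part of what the source reports. "The series", "measured", "known", "first", "only" and "open" are said of these compounds alone.

Measured so far:
compound 1 `CCCCCc1ccc(NS(=O)(=O)c2ccc(N3CCNC3=O)cc2)cc1` — 990 nM
compound 2 `CCc1ccc(NS(=O)(=O)c2ccc(N3CCNC3=O)cc2)cc1` — 660 nM
compound 3 `CCCCOc1ccc(NS(=O)(=O)c2ccc(N3CCNC3=O)cc2)cc1` — 630 nM

All three numbers come from a functional assay on HT-29 cells (Homo sapiens) for antiproliferative activity, read by sulforhodamine B assay, with a stated time of 48 h; on this read-out higher numbers stand for weaker inhibition and lower numbers for stronger inhibition. Compound 2 holds the second highest of the three, its nearest neighbour being compound 3 with a 1.0-fold lower number from compound 2 to compound 3 (0.02 log units; within the scatter) and its furthest compound 1 with a 1.5-fold lower number from compound 1 to compound 2 (0.18 log units; within the scatter); the three values are thus indistinguishable within the scatter.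

Compound 4 `COc1cccc(NS(=O)(=O)c2ccc(N3CCNC3=O)cc2)c1` has not been measured in this assay. Against compound 2 it differs by 3-methoxyphenyl in place of 4-ethylphenyl on a sulfonamide nitrogen.

Of the measured steps, the nearest relative is the step from compound 2 to compound 3 (butoxy in place of ethyl on an aromatic carbon), which stayed within the scatter, as did the step from compound 1 to compound 3 with a 1.6-fold lower number from compound 1 to compound 3 (0.20 log units; within the scatter). Going by the values given here, no measured pair, however, moves a group from one aromatic carbon to another or shortens the group to methoxy, so the present change is only partly covered. Since every change of the aryl substituent seen so far stayed within the scatter, the step from compound 2 to compound 4 is expected to be small, with a 1.1-fold higher number from compound 2 to compound 4 (0.06 log units; within the scatter) as the estimate. For compound 4 the expected value is 750 nM, in a range from 300 nM to 1900 nM.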

Compound 4, half-maximal inhibitory concentration: 120 nM
Compound 4: the middle estimate sits 6.3-fold (0.80 log units) above what was measured; measured number outside the range, below it.
By their numbers in this assay, from the lowest: compound 4; then compounds 3, 2 and 1 (each within the scatter of the next).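

In this assay, replacing 4-ethylphenyl with 3-methoxyphenyl on the sulfonamide nitrogen gives a 5.5-fold lower number from compound 2 to compound 4 (0.74 log units; beyond the scatter), the only step shown that lies beyond the scatter, whereas the steps among compound 1, compound 2 and compound 3 all stayed within it. The response at this position is therefore not flat: the aryl group on the sulfonamide nitrogen can move the number even when the leaving and entering groups both count 8 heavy atoms, the entering group differing by 1 oxygen and 1 hydrogen-bond acceptor. No measurement is available that bears on why this step is larger than the others.

The step changes both the substituent and its place on the ring, so the compounds shown cannot tell whether the methoxy group or its placement carries the shift; 4-methoxyphenyl and 3-ethylphenyl on the same nitrogen would separate the two. Also open, going by these compounds, is whether the lower number persists with other groups in the same place, such as 3-butoxyphenyl or 3-aminophenyl.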